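Removing the hydroxy group from compound 1

The source may report more compounds than this note shows. Statements on the series, on what has been measured and on what is new or still open speak of the compounds shown alone.

In a functional assay on CCRF-CEM cells (Homo sapiens) for antiproliferative activity, read by fluorescence and resazurin assay, with a stated time of 48 h (a lower number here means a stronger inhibitor, a higher number a weaker inhibitor), compound 1 (`O=C(N/N=C/c1cccnc1)c1cc2ccc(O)cc2oc1=O`) gives 14100 nM as its value, and compound 2 (`CCOc1ccc2nc(Cl)c(/C=N/NC(=O)c3cc4cc([N+](=O)[O-])ccc4oc3=O)cc2c1`) gives 15700 nM as its value. Going by the values given here, these are the only two numbers available so far. They lie within the scatter of each other, so compound 1 stands level with compound 2 and neither can be ranked. Compound 3 (`O=C(N/N=C/c1cccnc1)c1cc2ccccc2oc1=O`) has not yet been measured. It departs from compound 1 in one place only: hydrogen in place of hydroxy on an aromatic carbon. Among the compounds with values here, no measured pair isolates this change, so the data give no direct size for it. In this assay the expectation is a small shift towards a higher number, one that stays within the scatter. The expected step is a 1.3-fold higher number from compound 1 to compound 3 (0.11 log units; within the scatter) in size, an estimate and not a measurement. For compound 3 the estimated value is 18000 nM as a middle figure, with an expected range from 8000 nM to 45000 nM around it.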

Compound 3, half-maximal inhibitory concentration: 9900 nM
For compound 3 the middle estimate is 1.8-fold (0.26 log units) above the measured one, and the stated range covers the measured number.
By their numbers in this assay, from the lowest: compounds 3, 1 and 2 (each within the scatter of the next).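

Hydrogen in place of hydroxy on an aromatic carbon gives a 1.4-fold lower number from compound 1 to compound 3 (0.15 log units; within the scatter) in this assay, and this is the first pair in the series to isolate a single change. The hydroxy group, meta to a fused ring and para to a fused ring, is therefore not required at this place for a number at this level, and compound 1 and compound 3 stand level and cannot be ranked. Nothing available on these compounds bears on the reason for this result.

What the compounds shown leave open is whether any other group on this aromatic carbon, such as an amine, a methoxy group or a carboxylic acid, would move the number beyond the scatter, or whether this position simply has little bearing on the read-out. A single pair also cannot say whether the same exchange would stay as small with a different group elsewhere on the shared core.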